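Replacing pyridin-3-yl by phenyl: an expectation for compound 4

The source may report more compounds than this note shows. Statements on the series, on what has been measured and on what is new or still open speak of the compounds shown alone.

Compound 1 `O=C(Cc1cccnc1)c1ccccc1`: 15%
Compound 2 `CC(C(=O)c1ccccc1)c1cccnc1`: 44%
Compound 3 `OC(c1cccnc1)C(c1ccccc1)c1cccnc1`: 9%

Of the compounds shown here, three have been measured in an assay on isolated protein (adrenal gland) for inhibition of cytochrome P450 11B1, mitochondrial (Bos taurus), tested at 2 uM; on this read-out higher numbers stand for more inhibition at the one concentration tested (going by the name of the read-out) and lower numbers for less inhibition. Compound 3 gives the lowest number of the three, 9%, but compound 1 with 15% sits within the scatter of it; only compound 2 with 44% lies clearly apart. Among the compounds with values here, the single step measured so far, a number 29 percentage points higher from compound 1 to compound 2 (beyond the scatter), concerns a methyl in place of hydrogen on a saturated chain carbon bound to an aromatic carbon and a carbonyl carbon, a change of another kind.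

Compound 4 `OC(c1ccccc1)C(c1ccccc1)c1cccnc1` differs from compound 3 in one place: phenyl in place of pyridin-3-yl on a saturated chain carbon bound to an oxygen on a saturated carbon and a saturated chain carbon. Within the data shown here, no measured pair shows a pyridin-3-yl being exchanged for phenyl, so nothing here speaks for a step beyond the scatter in this assay. Compound 4 is therefore expected to stay close to compound 3, with an estimated step of a number 3 percentage points higher from compound 3 to compound 4 (within the scatter). The estimate for compound 4 in this assay is 12%, between 0% and 30%.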

Compound 4, a percentage reported as inhibition, at one concentration (the size of the read-out at that concentration, not a potency): 44%
The estimate for compound 4 lay 32 percentage points below the measured number, outside the stated range (above it).
By their numbers in this assay, from the lowest: compounds 3 and 1 (each within the scatter of the next); then compounds 2 and 4 (each within the scatter of the next).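

In this assay, the exchange of pyridin-3-yl for phenyl on a saturated chain carbon bound to an oxygen on a saturated carbon and a saturated chain carbon gives a number 35 percentage points higher from compound 3 to compound 4 (beyond the scatter), a large step. Within the data shown here, the earlier compounds held no exchange at this place, so this is the first sign that the read-out responds to the group here, and that it does so when one hydrogen-bond acceptor leaves and the number of heavy atoms stays the same. Nothing given here bears on the reason for this step.

On these data alone, whether a cyclohexyl or an aminophenyl at this place would keep the higher number remains open. So does whether the same exchange would give a step of this size on any other compound.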